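Changing the chain end of a weak benzoic acid analogue

The compounds below may be only part of what the source reports. "The series", "measured", "known", "first", "only" and "open" are said of these compounds alone.

Measured so far:
Compound 1 `CO[C@](C)(CCCC(C)C)c1ccc(Cc2c(C)cc(Oc3cc(C)cc(O)c3)cc2O)cc1O` — 15700 nM
Compound 2 `C=C(C)CCC[C@](C)(O)c1ccc(C(=O)O)cc1O` — "not active" (no number reported)

In a functional assay on HL-60 cells (Homo sapiens) for cytotoxicity, read by MTT assay, with a stated time of 72 h (a lower number here means a stronger inhibitor, a higher number a weaker inhibitor), compound 1 gives 15700 nM, while compound 2 is reported only as "not active" (no number reported), so no number places compound 2 on this scale. Compound 3 `CC(=O)OC[C@@H](C)CCC[C@](C)(O)c1ccc(C(=O)O)cc1O` differs from compound 2 by one change: 1-(acetoxymethyl)ethyl in place of 1-methylethenyl on a saturated chain carbon, four bonds along the chain from an aromatic carbon and an oxygen on a saturated carbon. Compound 2 shows no measurable activity, so the step to compound 3 cannot be sized; a shift beyond the scatter in either direction is possible but unsupported. Compound 3 is expected to give about 60000 nM, within 15000 nM to 250000 nM.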

Compound 3, half-maximal inhibitory concentration: "not active" (no number reported)
The entry for compound 3 holds no number, and the estimate cannot be compared.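

In this assay compound 2 and compound 3 are both reported only as not active, so no step can be read between them. Whether 1-(acetoxymethyl)ethyl in place of 1-methylethenyl changes activity at all stays open, and nothing shown here bears on this result.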